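A few compounds are considered here, and "the series" means these few. Any claim that something is new, unique, unknown or untested is made for them only; others in the source may bear on it.

Measured so far in an ADME assay on L1210/0 cells (Mus musculus) for cytotoxicity, with a stated time of 48 h; on this read-out higher numbers stand for weaker inhibition and lower numbers for stronger inhibition:

Compound 1, `Nc1nc(Cl)c2nnn([C@H]3CCCC[C@H]3CO)c2n1`, gives 95500 nM.
Compound 2, `Nc1nc(N)c2nnn([C@H]3CCCC[C@H]3CO)c2n1`, reaches only the limit of this assay, > 200000 nM.
Compound 3, `COC1=C(OC)C(O)(CCn2cnc3c(N)ncnc32)OC1=O`, likewise reaches only the limit of this assay, > 200000 nM.

Compound 1 and compound 2 share one core and differ in one place: chloro in place of amino on an aromatic carbon. This change gave an at least 2.0-fold lower number from compound 2 to compound 1 (0.32 log units; beyond the scatter), though the size of the step is bounded by the limit of > 200000 nM in this assay, at which 2 of the 3 values shown sit.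

Compound 4, `COC1=C(OC)C(O)(CCn2cnc3c(Cl)ncnc32)OC1=O`, is not yet measured. It stands to compound 3 as compound 1 stands to compound 2: chloro in place of amino on an aromatic carbon. It is the same kind of change, not the same one, since in compound 2 the place is also meta to an amino group (1 heavy atom), and the difference between the two cores is not broken down here.

In this assay compound 4 is expected to move by an at least 1.3-fold lower number from compound 3 to compound 4 (0.12 log units; that floor lies within the scatter), a step of about the size seen between compound 2 and compound 1, resting on an at least 2.0-fold lower number from compound 2 to compound 1 (0.32 log units; beyond the scatter). Compound 4 is therefore estimated at 150000 nM, between 50000 nM and 400000 nM, with a real chance that only a limit is reported.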

Compound 4, half-maximal inhibitory concentration: > 200000 nM
Compound 4 ended at the assay's limit; the forecaster's own chance of this, stated with the estimate: 55%; middle value at least 1.3-fold (0.12 log units) away from the limit.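

The step between compound 3 and compound 4 cannot be read, because both stop at a limit of the assay and neither gives a number: the limit of > 200000 nM in this assay, at which 3 of the 4 values shown sit.

The compounds shown leave open whether chloro in place of amino changes the result in this assay on the core of compound 3 at all, as the same kind of change gave an at least 2.0-fold lower number from compound 2 to compound 1 (0.32 log units; beyond the scatter) on the other core.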